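Replacing 4-bromophenyl with 3-nitrophenyl in a cytotoxic series

This account rests on a few compounds, and the source may have more. Where it says the series, first, only, none or still open, it means among the compounds named here.

Of the compounds shown here, three that share one core have been tested in a functional assay on MCF7 cells (Homo sapiens) for cytotoxicity, read by MTT assay, with a stated time of 72 h (a lower number here means a stronger inhibitor, a higher number a weaker inhibitor), so far. Compound 1 `CNC(=O)c1cc(Oc2ccc(C(=O)/C=C/c3ccc(OC)c(OC)c3OC)cc2)ccn1` gives 2910 nM and compound 3 `CNC(=O)c1cc(Oc2ccc(C(=O)/C=C/c3cc(OC)c(OC)c(OC)c3)cc2)ccn1` gives 3880 nM as two values within the usual scatter of each other. Compound 2 `CNC(=O)c1cc(Oc2ccc(C(=O)/C=C/c3ccc(Br)cc3)cc2)ccn1` stands at > 50000 nM as a limit of the assay and not a number.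

Compound 4 `CNC(=O)c1cc(Oc2ccc(C(=O)/C=C/c3cccc([N+](=O)[O-])c3)cc2)ccn1` has not been measured yet. It differs from compound 2 in one place, where 3-nitrophenyl takes the place of 4-bromophenyl on a double-bonded chain carbon bound to a double-bonded chain carbon. Among the compounds with values here, the counted change is 3-nitrophenyl in place of 4-bromophenyl on a double-bonded chain carbon bound to a double-bonded chain carbon and no measured pair isolates it, so any forecast is loose. Compound 3 at 3880 nM does show that this core can give a real number. A modest move towards stronger inhibition in this assay is therefore expected, with an estimated step of an at least 2.5-fold lower number from compound 2 to compound 4 (0.39 log units; beyond the scatter) in all. For compound 4 the expected value is 20000 nM with an estimated range from 6000 nM to 50000 nM for a single measurement.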

Compound 4, half-maximal inhibitory concentration: > 50000 nM
Compound 4: a limit, no number; the forecaster's own chance of this, stated with the estimate: 35%; at least 2.5-fold (0.39 log units) between middle value and limit.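

Compound 2 and compound 4 both end at a limit of the assay and not at a number, so no step between them can be read: the limit of > 50000 nM in this assay, at which 2 of the 4 values shown sit.

The compounds shown leave open whether 3-nitrophenyl in place of 4-bromophenyl changes the inhibition at all, and by how much.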